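This account rests on a few compounds, and the source may have more. Where it says the series, first, only, none or still open, it means among the compounds named here.

Measured so far in an assay on aorta for inhibition of acyl-CoA:cholesterol acyltransferase (Oryctolagus cuniculus); a higher number here means a weaker inhibitor, a lower number a stronger inhibitor: compound 1, `CCNC(=O)Nc1c(OCCCn2cnc(-c3ccccc3)c2)cccc1N(C)C`; compound 2, `CCCNC(=O)Nc1c(OCCCn2cnc(-c3ccccc3)c2)cccc1N(C)C`; compound 3, `CCCCCNC(=O)Nc1c(OCCCn2cnc(-c3ccccc3)c2)cccc1N(C)C`.

In this assay compound 1 reaches only a limit of the assay, > 10000 nM. Compound 2 gives 7230 nM, and compound 3 gives 160 nM. Of the two numbers shown, compound 3 has the lowest; its nearest neighbour is compound 2, and that step is a 45-fold lower number from compound 2 to compound 3 (1.66 log units; beyond the scatter). The step of an at least 1.3-fold lower number from compound 1 to compound 2 (0.14 log units; that floor lies within the scatter), and the step of an at least 62-fold lower number from compound 1 to compound 3 (1.79 log units; beyond the scatter), runs against a value that is a limit (the limit of > 10000 nM in this assay, at which 1 of the 3 values shown sits). All three measured steps lengthen the chain on the far side of the urea while the urea itself stays.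

Compound 4, `CCCCCCNc1c(OCCCn2cnc(-c3ccccc3)c2)cccc1N(C)C`, changes something else: hexyl in place of pentylcarbamoyl on a nitrogen on an aromatic ring. Among the measured compounds shown here, no measured step bears on removing the carbonyl and the chain-side amide nitrogen, so the measured steps give no direct guide. On that footing, compound 4 is expected to give a weaker result, a step of a 19-fold higher number from compound 3 to compound 4 (1.27 log units; beyond the scatter). The estimate for compound 4 is 3000 nM, with a range from 300 nM to 30000 nM.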

Compound 4, half-maximal inhibitory concentration: 3300 nM
For compound 4 the middle estimate is 1.1-fold (0.04 log units) below the measured one; the range from low to high includes it.
By their numbers in this assay, from the lowest: compound 3; then compound 4; then compound 2. At a limit, above all of these: compound 1.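

In this assay, hexyl in place of pentylcarbamoyl on a nitrogen on an aromatic ring gives a 21-fold higher number from compound 3 to compound 4 (1.31 log units; beyond the scatter), so a long carbon chain at this position does not on its own match the long-chain urea. The urea is not indispensable to measurable inhibition, however, as the change from a shorter urea gives a 2.2-fold lower number from compound 2 to compound 4 (0.34 log units; beyond the scatter). The comparison with the shortest urea gives an at least 3.0-fold lower number from compound 1 to compound 4 (0.48 log units; beyond the scatter), and that step runs against the assay limit of compound 1: the limit of > 10000 nM in this assay, at which 1 of the 4 values shown sits.

The compounds shown leave open whether the difference between the urea and the hexylamino compound follows from the carbonyl, the chain-side nitrogen or the chain itself. A simple pentylamino group, an amide with a hexyl chain, or a urea with a chain longer than pentyl would each test a separate part of this.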